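The source may hold more compounds than are shown below. What is called first, only, known or untested is meant among the compounds shown, and "the series" means these compounds.

Of the compounds shown here, three that share one core have been measured in an assay on Huh-7 cells for agonist activity at Bile acid receptor (Homo sapiens), read by a luciferase reporter; on this read-out lower numbers stand for an effect already at smaller amounts and higher numbers for an effect only at larger amounts of compound. Compound 1 `CC(C)c1onc(-c2c(Cl)cccc2Cl)c1COc1ccc(-c2nc3ccc(C(=O)O)cc3n2C(C)C)cc1` gives 3.39 nM in this assay, the lowest of the three numbers. Compound 2 `CC(C)c1onc(-c2c(Cl)cccc2Cl)c1COc1ccc(-c2nc3ccc(C(=O)O)cc3n2C2CCCCCC2)cc1` gives 14.8 nM, and compound 3 `CC(C)Cn1c(-c2ccc(OCc3c(-c4c(Cl)cccc4Cl)noc3C(C)C)cc2)nc2ccc(C(=O)O)cc21` gives 5.26 nM. Between them there is a 4.4-fold higher number from compound 1 to compound 2 (0.64 log units; beyond the scatter), whereas there is only a 1.6-fold higher number from compound 1 to compound 3 (0.19 log units; within the scatter). Compound 4 `CC(C)c1onc(-c2c(Cl)cccc2Cl)c1COc1ccc(-c2nc3ccc(C(=O)O)cc3n2C2CCCCC2)cc1` has not yet been measured. It differs from compound 1 in one place: cyclohexyl in place of isopropyl on an aromatic nitrogen. Both measured steps that bear on this change start from compound 1 and replace the same isopropyl with a larger group on the aromatic nitrogen. The isobutyl of compound 3 brought nothing beyond the scatter, while the cycloheptyl of compound 2 brought a modest rise in the number. Since cyclohexyl, a six-membered non-aromatic ring of carbon only, resembles the cycloheptyl of compound 2 more than the isobutyl of compound 3, a rise beyond the scatter is expected, yet a smaller one than a 4.4-fold higher number from compound 1 to compound 2 (0.64 log units; beyond the scatter). The expected step is a 2.5-fold higher number from compound 1 to compound 4 (0.40 log units; beyond the scatter). Compound 4 is therefore estimated at 8.5 nM, with a range from 4 nM to 18 nM.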

Compound 4, half-maximal effective concentration: 4.21 nM
For compound 4 the middle estimate is 2.0-fold (0.31 log units) above the measured one; measured number inside the range.
By their numbers in this assay, from the lowest: compounds 1, 4 and 3 (each within the scatter of the next); then compound 2.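

In this assay, a six-membered ring of carbon only on this aromatic nitrogen stays within the scatter of both open-chain groups, the isopropyl (a 1.2-fold higher number from compound 1 to compound 4 (0.09 log units; within the scatter)) and the isobutyl (a 1.2-fold lower number from compound 3 to compound 4 (0.10 log units; within the scatter)). A ring at this position therefore need not raise the number, and among these four compounds only the cycloheptyl of compound 2 stands apart, as the step to cyclohexyl shows (a 3.5-fold lower number from compound 2 to compound 4 (0.55 log units; beyond the scatter)). Nothing available explains why the cycloheptyl behaves differently from the cyclohexyl.

All the groups shown on this nitrogen contain only carbon, so it stays open how a ring holding oxygen, such as tetrahydropyranyl, or an aromatic phenyl ring would read here. Also open, going by these compounds, is whether a smaller ring, such as cyclopentyl, would stay within the scatter of compound 1.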